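The compounds below may be only part of what the source reports. "The series", "measured", "known", "first", "only" and "open" are said of these compounds alone.

Measured compounds in an ADME assay on Huh-5-2 cells (Homo sapiens) for cytotoxicity, read by WST assay, with a stated time of 3 days; a higher number here means that more compound is tolerated, a lower number that less compound is tolerated:
compound 1, `O=c1c(O)c(-c2ccccc2)oc2cc(OCc3ccccc3Br)cc(O)c12`, gives > 100000 nM; this is a limit of the assay, not a number.
compound 2, `COc1ccccc1COc1cc(O)c2c(=O)c(O)c(-c3ccccc3)oc2c1`, gives > 100000 nM; this too is a limit of the assay.
compound 3, `Cc1cccc(COc2cc(O)c3c(=O)c(O)c(-c4ccccc4)oc3c2)c1`, gives 35000 nM.

Among the measured compounds shown here, compound 3 holds the only number in this assay; the two other values rest at a limit (the limit of > 100000 nM in this assay, at which 2 of the 3 values shown sit). Compound 4, `O=c1c(O)c(-c2ccccc2)oc2cc(OCc3ccc(Cl)cc3)cc(O)c12`, is not yet measured. It differs from compound 3 by 4-chlorophenyl in place of 3-methylphenyl on a saturated chain carbon bound to an oxygen on an aromatic ring. For the measured compounds named here, no measured step involves a chlorine on this ring. Going by the values given here, the steps that bear on the position are those that alter the same benzyl-linked ring: an at least 2.8-fold lower number from compound 1 to compound 3 (0.45 log units; beyond the scatter) and an at least 2.8-fold lower number from compound 2 to compound 3 (0.45 log units; beyond the scatter), each at least modest and in the downward direction. The swap from 3-methylphenyl to 4-chlorophenyl is a different change from either of those, so neither step reads onto its direction. The expectation for compound 4 in this assay is therefore a value close to that of compound 3, with no step beyond the scatter expected a 1.4-fold higher number from compound 3 to compound 4 (0.15 log units; within the scatter). The estimate for compound 4 is 50000 nM, with a range from 20000 nM to 100000 nM.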

Compound 4, half-maximal cytotoxic concentration: > 100000 nM
Compound 4: only a limit was reported (the forecaster's own chance of this, stated with the estimate: 40%); middle value at least 2.0-fold (0.30 log units) from the limit.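

In this assay, 4-chlorophenyl in place of 3-methylphenyl on the saturated chain carbon gives an at least 2.8-fold higher number from compound 3 to compound 4 (0.45 log units; beyond the scatter), so a change on this ring can move the number upward from compound 3. Compound 4 gives > 100000 nM, which is a limit of the assay and not a number, and its steps from compound 1 and compound 2 join two limits and cannot be read. Among the rings shown, 3-methylphenyl in compound 3 alone gives a number, while the bromo, methoxy and chloro rings of the other compounds all rest at the limit: the limit of > 100000 nM in this assay, at which 3 of the 4 values shown sit.

The swap changes both the group and its place on the ring, so the compounds shown do not tell which of the two matters. From the compounds shown here alone, a 4-methylphenyl, a 3-chlorophenyl or a ring carrying an amine has no value here, and how far compound 1, compound 2 and compound 4 lie past the limit stays open.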